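The source may report more compounds than this note shows. Statements on the series, on what has been measured and on what is new or still open speak of the compounds shown alone.

In a functional assay (aorta) for inhibition, with Rattus norvegicus as the target (a higher number here means a weaker inhibitor, a lower number a stronger inhibitor), compound 3 `COC(=O)CC/N=C(\S)[C@]1(c2cccnc2)CCCC[S+]1[O-]` gives > 30000 nM, which is a limit of the assay and not a number. Compound 1 `CCC/N=C(\S)[C@]1(c2cccnc2)CCCC[S+]1[O-]` gives 600 nM and compound 2 `CC(C)/N=C(\S)[C@]1(c2cccnc2)CCCC[S+]1[O-]` gives 10000 nM. Compound 3 sits at the weak end of these three, with an at least 50-fold higher number from compound 1 to compound 3 (1.69 log units; beyond the scatter) and an at least 3.0-fold higher number from compound 2 to compound 3 (0.47 log units; beyond the scatter). The remaining measured step is a 17-fold higher number from compound 1 to compound 2 (1.22 log units; beyond the scatter).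

The next structure is compound 4 `O=C(O)CC/N=C(\S)[C@]1(c2cccnc2)CCCC[S+]1[O-]`, and the change is hydrogen in place of methyl on an oxygen next to a carbonyl group, so methoxycarbonyl becomes carboxy. For the measured compounds named here, no measured step makes this change. The nearest evidence is the two steps into compound 3, both toward a higher number in this assay, and neither offers grounds to expect a recovery. No step beyond the scatter is expected in either direction, and the estimate is a number no higher from compound 3 to compound 4 (the limit leaves the size open). For compound 4 the expected value is 30000 nM, with an estimated range from 8000 nM to 100000 nM.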

Compound 4, concentration for 90% inhibition: > 30000 nM
Compound 4: no number, only a limit (the forecaster's own chance of this, stated with the estimate: 70%); the middle value lies on the limit itself.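

In this assay compound 4 gives > 30000 nM, which is a limit of the assay and not a number. The step from methoxycarbonyl to carboxy cannot be read, because both compounds sit at the same limit, so this change at the oxygen shows no direction: the limit of > 30000 nM in this assay, at which 2 of the 4 values shown sit. The carboxy chain end nevertheless stays well on the weak side of the propyl and isopropyl groups, with an at least 50-fold higher number from compound 1 to compound 4 (1.69 log units; beyond the scatter) and an at least 3.0-fold higher number from compound 2 to compound 4 (0.47 log units; beyond the scatter), so this change brings no visible return toward the propyl value.

On these data alone, how far the methoxycarbonyl and carboxy compounds lie past the limit stays open, and the two cannot be ranked. Also open, as far as these compounds go, is whether a longer straight chain such as butyl, or an amine at the chain end, would match or improve on compound 1 at 600 nM.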